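From pyridin-3-yl to bromo: what compound 4 may show

The source may hold more compounds than are shown below. What is called first, only, known or untested is meant among the compounds shown, and "the series" means these compounds.

Among the compounds with values here, compound 3 `N#Cc1ccc(NC(=O)c2ccc(-c3cccnc3)cc2O)cc1` gives 7940 nM in a functional assay on KG-1 cells (Homo sapiens) for cytotoxicity, read by luminescence and CellTiter-Glo, with a stated time of 3 days (a lower number here means a stronger inhibitor, a higher number a weaker inhibitor), the highest of the three numbers measured so far; compound 2 `O=C(Nc1cc(F)cc(F)c1)c1ccc2cccnc2c1O` gives 3340 nM and compound 1 `N#Cc1ccc(NC(=O)c2ccc(F)cc2O)cc1` gives 3150 nM, both beyond the scatter below compound 3. Compound 4 `N#Cc1ccc(NC(=O)c2ccc(Br)cc2O)cc1` differs from compound 3 in one place: bromo in place of pyridin-3-yl on an aromatic carbon. Within the data shown here, one measured step bears on this change, a 2.5-fold higher number from compound 1 to compound 3 (0.40 log units; beyond the scatter), in which pyridin-3-yl replaced fluoro. Compound 4 carries bromo where compound 1 carries fluoro, so the change is expected to undo most of that step and bring the number back toward compound 1. Compound 4 is therefore expected to give 3200 nM in this assay, within a likely range of 1500 nM to 7000 nM, meaning that a 2.5-fold lower number from compound 3 to compound 4 (0.39 log units; beyond the scatter) is expected as a modest drop.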

Compound 4, half-maximal inhibitory concentration: 1450 nM
The estimate for compound 4 lay 2.2-fold (0.34 log units) above the measured number, and the stated range ends above it.
By their numbers in this assay, from the lowest: compound 4; then compounds 1 and 2 (each within the scatter of the next); then compound 3.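

Bromo on this aromatic carbon gives a 5.5-fold lower number from compound 3 to compound 4 (0.74 log units; beyond the scatter) and also a 2.2-fold lower number from compound 1 to compound 4 (0.34 log units; beyond the scatter), so the two halogens are not interchangeable here, a difference the earlier compounds could not show. Among the three groups tested at this place on the shared core, bromo gives the lowest number and pyridin-3-yl the highest. Nothing available explains this order. The compounds shown leave open how chloro, iodo or a methyl group would rank at this carbon. They also leave open whether an amine or a carboxylic acid here would follow the same order.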